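Cytotoxicity of a salicyloyl imide series on rat L6 cells

This account rests on a few compounds, and the source may have more. Where it says the series, first, only, none or still open, it means among the compounds named here.

Measured so far:
Compound 1, `Cc1ccc(C(=O)NC(=O)c2ccccc2O)cc1`, gives 46 ug/mL in an ADME assay on L6 cells (Rattus norvegicus) for cytotoxicity, read by resazurin assay, with a stated time of 72 h; a lower number here means a stronger inhibitor, a higher number a weaker inhibitor.
Compound 2, `COC(=O)c1ccc(C(=O)NC(=O)c2ccccc2O)cc1`, gives 42 ug/mL in this assay.
Compound 3, `CCN(CC)c1ccc(C(=O)NC(=O)c2ccccc2O)cc1`, gives 8.2 ug/mL in this assay.

Compound 1 has the highest number of the three. The step of a 1.1-fold lower number from compound 1 to compound 2 (0.04 log units; within the scatter) is within the scatter, so compounds 1 and 2 cannot be told apart. The step of a 5.6-fold lower number from compound 1 to compound 3 (0.75 log units; beyond the scatter) is beyond the scatter, and so is a 5.1-fold lower number from compound 2 to compound 3 (0.71 log units; beyond the scatter), so compound 3 is the only one clearly set apart, with the lower number.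

Compound 4, `Nc1ccc(C(=O)NC(=O)c2ccccc2O)cc1`, has not yet been measured in this assay. Its difference from compound 1 is amino in place of methyl on an aromatic carbon.

Among the measured compounds shown here, two measured steps bear on this change, both starting from compound 1. Replacing methyl by methoxycarbonyl gave a 1.1-fold lower number from compound 1 to compound 2 (0.04 log units; within the scatter), while replacing methyl by diethylamino gave a 5.6-fold lower number from compound 1 to compound 3 (0.75 log units; beyond the scatter). For the measured compounds named here, the amino group, like diethylamino, places a nitrogen on the ring, but it is the smaller group and carries a hydrogen-bond donor; no measured compound shows that exact substituent. A modest lowering of the number is therefore expected, smaller than the step to compound 3.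

For compound 4 the expected value is 25 ug/mL, within a range of 10 ug/mL to 60 ug/mL, which means an expected step of a 1.8-fold lower number from compound 1 to compound 4 (0.26 log units; within the scatter).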

Compound 4, half-maximal inhibitory concentration: 39 ug/mL
For compound 4 the middle estimate is 1.6-fold (0.19 log units) below the measured one; the range from low to high includes it.
By their numbers in this assay, from the lowest: compound 3; then compounds 4, 2 and 1 (each within the scatter of the next).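

In this assay, amino in place of methyl on this aromatic carbon gives a 1.2-fold lower number from compound 1 to compound 4 (0.07 log units; within the scatter) and amino in place of methoxycarbonyl gives a 1.1-fold lower number from compound 2 to compound 4 (0.03 log units; within the scatter), so compound 4 cannot be told apart from compound 1 or compound 2. Among the compounds shown here, until now, the one nitrogen-bearing group on this carbon, the diethylamino of compound 3, went with the clearly lower number, but compound 4 shows that a nitrogen at this place does not by itself bring that result. Amino in place of diethylamino gives a 4.8-fold higher number from compound 3 to compound 4 (0.68 log units; beyond the scatter), which ties the separation of compound 3 to diethylamino as a whole among these four compounds, while no measurement shown here gives a reason for the difference.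

Still open, going by these compounds, is how much of the nitrogen's substitution is needed, which ethylamino, with a single ethyl chain on the nitrogen, or dimethylamino could help to show, as could a ring amine such as piperidine. Also open, on these data alone, is whether a diethylamino group would have the same effect on another carbon of this ring, and whether a carboxylic acid or a hydroxyl group on the same carbon would stay with compounds 1, 2 and 4 or move toward compound 3.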